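The source may hold more compounds than are shown below. What is called first, only, known or untested is meant among the compounds shown, and "the series" means these compounds.

Working notes on the series in a functional assay on HepG2 cells (Homo sapiens) for antiproliferative activity, read by MTT assay, with a stated time of 48 h; on this read-out lower numbers stand for stronger inhibition and higher numbers for weaker inhibition. Compound 1 `O=C(CN1CCCCC1)Nc1ccc2ncnc(Nc3cccc(C(F)(F)F)c3)c2c1` returns only a limit in this assay, > 100000 nM. Compound 2 `CN1CCN(CC(=O)Nc2ccc3ncnc(Nc4cccc(C(F)(F)F)c4)c3c2)CC1` likewise returns only a limit in this assay, > 100000 nM. Within the data shown here, compound 3 `O=C(CN1CCCCC1)Nc1ccc2ncnc(Nc3cccc(Cl)c3)c2c1` is the one member with a number, giving 12000 nM in this assay. The core of compound 3 differs from the core of compound 1 by chloro in place of trifluoromethyl on an aromatic carbon, a change that gives an at least 8.3-fold lower number from compound 1 to compound 3 (0.92 log units; beyond the scatter). Compound 2 differs from compound 1 by 4-methylpiperazin-1-yl in place of piperidin-1-yl on a saturated chain carbon bound to a carbonyl carbon; the resulting step, a step that the two limits leave unreadable from compound 1 to compound 2, cannot be sized, since the limit of > 100000 nM in this assay, at which 2 of the 3 values shown sit, sits at both of its ends. Compound 4 `CN1CCN(CC(=O)Nc2ccc3ncnc(Nc4cccc(Cl)c4)c3c2)CC1` carries the same change set on the core of compound 3, (4-methylpiperazin-1-yl in place of piperidin-1-yl on a saturated chain carbon bound to a carbonyl carbon); the two place descriptions match word for word, so it is the same change, not merely the same kind. With the measured pair giving no readable size for this change, the step is expected to be small: a 1.3-fold higher number from compound 3 to compound 4 (0.10 log units; within the scatter) is the estimated step for compound 4 in this assay. This expectation rests on compound 3 at 12000 nM as the only numbered anchor. Compound 4 is therefore expected to give 15000 nM, with a range from 4000 nM to 60000 nM.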

Compound 4, half-maximal inhibitory concentration: > 100000 nM
Compound 4 was reported as a limit; the forecaster's own chance of this, stated with the estimate: 25%; at least 6.6-fold (0.82 log units) between middle value and limit.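

On the core of compound 3, 4-methylpiperazin-1-yl in place of piperidin-1-yl gives an at least 8.3-fold higher number from compound 3 to compound 4 (0.92 log units; beyond the scatter), so on this core the change weakens inhibition in this assay by more than the usual scatter. Compound 4 is reported only as a limit, so this size is a lower bound and not a measured step. The same change on the core of compound 1 and the step from compound 2 to compound 4 cannot be read, which leaves it unshown whether the change has a similar size on both cores, and most of the series gives no number to compare: the limit of > 100000 nM in this assay, at which 3 of the 4 values shown sit.

As far as these compounds go, it remains open whether morpholin-4-yl or dimethylamino in place of piperidin-1-yl would stay near compound 3 at 12000 nM or read like compound 4. Also open, from the compounds shown here alone, is how a longer chain on the carbonyl carbon, or bromo or fluoro in place of chloro, would read on this core.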